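Swapping Bromo for Trifluoromethoxy: What to Expect

The source may hold more compounds than are shown below. What is called first, only, known or untested is meant among the compounds shown, and "the series" means these compounds.

Compound 1, `COc1cc(OC)c2c(=O)cc(/C=C/c3ccc(Cl)cc3)oc2c1`: 14200 nM
Compound 2, `COc1ccc2c(=O)cc(/C=C/c3ccc(OC(F)(F)F)cc3)oc2c1`: 9900 nM
Compound 3, `COc1cc(OC)c2c(=O)cc(/C=C/c3ccc(Br)cc3)oc2c1`: > 40000 nM

All three compounds were tested in a functional assay on HeLa cells (Homo sapiens) for antiproliferative activity, read by MTT assay, with a stated time of 12 h; a lower number here means a stronger inhibitor, a higher number a weaker inhibitor. For compound 3 the result is only a limit of the assay, > 40000 nM, so no exact number is known. Compound 3 therefore sits at the limit of > 40000 nM in this assay, at which 1 of the 3 values shown sits, the weakest reading among the values shown. Among the measured compounds shown here, the one measured step that involves compound 3 is an at least 2.8-fold higher number from compound 1 to compound 3 (0.44 log units; beyond the scatter), a change of bromo in place of chloro on an aromatic carbon.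

The next compound, compound 4, `COc1cc(OC)c2c(=O)cc(/C=C/c3ccc(OC(F)(F)F)cc3)oc2c1`, keeps the core of compound 3 and changes one group: trifluoromethoxy in place of bromo on an aromatic carbon.

For the measured compounds named here, no measured step covers exactly this change. Going by the values given here, the only step available, an at least 2.8-fold higher number from compound 1 to compound 3 (0.44 log units; beyond the scatter), compares two halogens and does not involve trifluoromethoxy. Compound 2, which carries trifluoromethoxy on a different core, gives 9900 nM, which hints that this group is compatible with a measurable number. On that basis the expected step is an at least 2.6-fold lower number from compound 3 to compound 4 (0.42 log units; beyond the scatter), a move toward a stronger inhibitor, though with wide uncertainty since compound 3 itself has only a limit.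

The estimate for compound 4 in this assay is 15000 nM, expected to fall between 5000 nM and 45000 nM.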

Compound 4, half-maximal inhibitory concentration: > 40000 nM
Compound 4 gave a limit, no number (the forecaster's own chance of this, stated with the estimate: 30%); middle value at least 2.6-fold (0.42 log units) from the limit.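

In this assay, trifluoromethoxy in place of chloro gives an at least 2.8-fold higher number from compound 1 to compound 4 (0.44 log units; beyond the scatter), so on this core the weak reading at this place, on an aromatic carbon para to a large group, is not confined to bromo. Compound 2 had suggested that trifluoromethoxy could give a measurable number, but methoxy in place of hydrogen on an aromatic carbon, with trifluoromethoxy kept, gives an at least 4.0-fold higher number from compound 2 to compound 4 (0.60 log units; beyond the scatter), so that number did not carry over to the core with the added methoxy. Among the three compounds on this core that differ only at this place, chloro is the only group so far that gives a number rather than a limit.

Going by these compounds, the step between bromo and trifluoromethoxy cannot be read, and how far compound 3 and compound 4 differ stays open, because both stop at the same limit: the limit of > 40000 nM in this assay, at which 2 of the 4 values shown sit. Also open, on these data alone, is whether an amine or a carboxylic acid at this same place on the shared core would give a number, and whether such a number would be lower or higher than the one for chloro.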